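Swapping an anilide for a lactam on a fused core

The compounds below may be only part of what the source reports. "The series", "measured", "known", "first", "only" and "open" are said of these compounds alone.

Measured so far:
compound 1, `O=C(Nc1ccccc1)c1cnc(NCc2c(F)ccc3c2CCO3)n2cnnc12`: 14 mL.min-1.g-1
compound 2, `CC(=O)N1CCC(c2cnc(NCc3c(F)ccc4c3CCO4)c3cn[nH]c(=O)c23)CC1`: 207 mL.min-1.g-1

In an ADME assay on microsomes from liver (Homo sapiens) for metabolic stability, read by LC-MS, using NADPH, with stated times of 5 min and 30 min, tested at 1 uM (a lower number here means slower removal, a higher number faster removal of the compound), compound 1 gives 14 mL.min-1.g-1, the lower of the two numbers. Among the measured compounds shown here, compound 2 gives 207 mL.min-1.g-1, a gap beyond the usual scatter, though the two share only part of their structure and no single-change step links them.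

Compound 3, `C[C@@H]1CC(=O)N(c2cnc(NCc3c(F)ccc4c3CCO4)n3cnnc23)C1`, keeps the shared core of compound 1 and changes one place: 4-methyl-2-oxopyrrolidin-1-yl in place of phenylcarbamoyl on an aromatic carbon. A group with one hydrogen-bond donor leaves and a group with none enters, and the entering group carries one defined stereocentre.

For the measured compounds named here, no measured pair shows what such a swap does in this assay, so the expectation rests on the value of compound 1 alone. A modest upward step is expected, one that may or may not clear the scatter, since compound 1 sits at 14 mL.min-1.g-1 and the change is a substantial reshaping of that side of the molecule. Compound 3 is therefore estimated at 25 mL.min-1.g-1, with a range of 8 mL.min-1.g-1 to 80 mL.min-1.g-1, which would mean a step of a 1.8-fold higher number from compound 1 to compound 3 (0.25 log units; within the scatter).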

Compound 3, intrinsic clearance in microsomes: < 3 mL.min-1.g-1
Compound 3 ended at the assay's limit (the forecaster's own chance of this, stated with the estimate: 5%); at least 8.3-fold (0.92 log units) between middle value and limit.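

In this assay compound 3 gives < 3 mL.min-1.g-1, which is a limit of the assay and not a number. Among the compounds shown here, this is the first comparison that differs in one place, and it shows that the group on this aromatic carbon of the shared core can by itself move the read-out: 4-methyl-2-oxopyrrolidin-1-yl in place of phenylcarbamoyl gives an at least 4.6-fold lower number from compound 1 to compound 3 (0.66 log units; beyond the scatter). That step is only a minimum, so its full size cannot be read: the limit of < 3 mL.min-1.g-1 in this assay, at which 1 of the 3 values shown sits.

The swap changes several things at once: the six-membered aromatic ring leaves, the hydrogen-bond donor is lost, the ring becomes a five-membered lactam, and a methyl group with a defined stereocentre arrives, so the compounds shown cannot say which of these matters. From the compounds shown here alone, it also stays open what this carbon would give with a 2-oxopyrrolidin-1-yl lacking the methyl group, with the opposite configuration at the methyl-bearing carbon, or with a simple amine.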